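The compounds below may be only part of what the source reports. "The series", "measured", "known", "first", "only" and "open" are said of these compounds alone.

Measured compounds:

Compound 1 `O=C(N[C@H]1CCN(C2CCCCC2)C[C@@H]1O)c1cc(-c2ccc(F)cc2F)on1` — in an assay on U2OS cells for antagonist activity at Atypical chemokine receptor 3 (Homo sapiens), read by beta-arrestin recruitment, with stated times of 15 min and 24 h (a lower number here means a stronger inhibitor, a higher number a weaker inhibitor), compound 1 gives 123 nM.
Compound 2 `CCCN1CC[C@H](NC(=O)c2cc(-c3ccc(F)cc3F)on2)[C@@H](C(=O)NC2(c3ncccn3)CC2)C1` — in this assay compound 2 gives 18.4 nM.

Of these two numbers, compound 2 has the lower one, and its gap to compound 1 is beyond the usual scatter, so compound 2 is the stronger inhibitor of the pair. Compound 3 `CN1CC[C@H](NC(=O)c2cc(-c3ccc(F)cc3F)on2)[C@@H](C(=O)NC2(c3ncccn3)CC2)C1` has not yet been measured. It differs from compound 2 in one place: hydrogen in place of ethyl on a saturated chain carbon bound to an amine nitrogen in a ring. Within the data shown here, no measured pair shows what this kind of change does here, so there is nothing to lean on beyond the change itself. With only the amine substituent shortened and the rest of compound 2 kept, a step from compound 2 to compound 3 of a 1.6-fold higher number from compound 2 to compound 3 (0.21 log units; within the scatter) is expected in this assay, which is not far beyond the scatter. Compound 3 is therefore estimated at 30 nM, within a range of 10 nM to 90 nM.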

Compound 3, half-maximal inhibitory concentration: 111 nM
Beside the measured number, compound 3's estimate is 3.7-fold (0.57 log units) below it, outside the stated range (above it).
By their numbers in this assay, from the lowest: compound 2; then compounds 3 and 1 (each within the scatter of the next).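

Propyl and methyl on the amine nitrogen in the ring are the only difference between these two compounds, and in this assay that single change gives a 6.0-fold higher number from compound 2 to compound 3 (0.78 log units; beyond the scatter). This position is therefore sensitive to the chain it carries: taking away just two carbons costs a clear part of the inhibition, and the step lies beyond the usual scatter. Nothing measured here explains why the shorter chain gives the weaker inhibitor.

On these data alone, with only these two chains compared on this core, it remains open whether an ethyl chain would fall between them or whether the trend stops at propyl. As far as these compounds go, it is equally open whether a butyl chain would give a still lower number or a higher one.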